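Notes on 3-bromophenyl and 4-bromophenyl in the series

The source may report more compounds than this note shows. Statements on the series, on what has been measured and on what is new or still open speak of the compounds shown alone.

- compound 1 `CC(C)=CCOc1ccc2c(c1)OC(c1ccccc1Cl)CC2=O` gives 8020 nM
- compound 2 `CC(C)=CCOc1ccc2c(c1)OC(c1cccc(Br)c1)CC2=O` gives 5280 nM

In a functional assay (on this read-out higher numbers stand for weaker inhibition and lower numbers for stronger inhibition), compound 2 stands at 5280 nM, within the scatter of compound 1 , so these two numbers set no order. The next compound is compound 3 `CC(C)=CCOc1ccc2c(c1)OC(c1ccc(Br)cc1)CC2=O`, and the change is 4-bromophenyl in place of 3-bromophenyl on a saturated ring carbon. It puts 4-bromophenyl in place of 3-bromophenyl on a saturated ring carbon, next to the ring oxygen. Among the compounds with values here, the only measured step at this place is a 1.5-fold lower number from compound 1 to compound 2 (0.18 log units; within the scatter), and no measured compound carries 4-bromophenyl. Resting on that one small step, no change beyond the scatter is expected in this assay, and no direction can be favoured. The expected size of the change is a 1.1-fold lower number from compound 2 to compound 3 (0.02 log units; within the scatter). For compound 3 the estimate is 5000 nM, with an expected range of 2000 nM to 12000 nM.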

Compound 3, half-maximal inhibitory concentration: 8120 nM
For compound 3 the middle estimate is 1.6-fold (0.21 log units) below the measured one; low and high end bracket the measured number.
By their numbers in this assay, from the lowest: compounds 2, 1 and 3 (each within the scatter of the next).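

In this assay, 4-bromophenyl in place of 3-bromophenyl on the saturated ring carbon gives a 1.5-fold higher number from compound 2 to compound 3 (0.19 log units; within the scatter), and 4-bromophenyl in place of 2-chlorophenyl gives a 1.0-fold higher number from compound 1 to compound 3 (0.01 log units; within the scatter), so the three compounds now set no order among themselves. Within the data shown here, the new pair is the first to change only the place of the halogen on the phenyl ring, and that change stays within the scatter, as does the step from compound 1, where the halogen and its place change together. Nothing at hand bears on why these numbers stay so close.

Open, as far as these compounds go, is whether a group of another kind at this carbon, such as a phenyl carrying an amine or a carboxylic acid, would move the number beyond the scatter. No pair shown compares chlorine and bromine at the same place on the phenyl ring, so the halogen itself remains unseparated from its place.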